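Removing a Silyl Cap from a Triazole Side Chain

This account rests on a few compounds, and the source may have more. Where it says the series, first, only, none or still open, it means among the compounds named here.

Compound 1 `CCOC(CCn1c(Cc2nn(C)c(=O)c3ccccc23)nnc1SCCCCCCCC(=O)Nc1ccc(Cl)cc1Cl)OCC`: 16400 nM
Compound 2 `Cn1nc(Cc2nnc(SCC(=O)Nc3ccc(Cl)cc3Cl)n2CCCO)c2ccccc2c1=O`: > 30000 nM
Compound 3 `Cn1nc(Cc2nnc(SCCCCCCCC(=O)Nc3ccc(Cl)cc3Cl)n2CCCO[Si](C)(C)C(C)(C)C)c2ccccc2c1=O`: > 30000 nM

In an assay on 32D cells for inhibition of interleukin-15 (Mus musculus), read by resazurin assay, with stated times of 30 min and 2.5 days, in the presence of a further agent that is not named here (on this read-out higher numbers stand for weaker inhibition and lower numbers for stronger inhibition), compound 3 gives only the limit > 30000 nM, not a number. Among the measured compounds shown here, compound 2 also sits at a limit, > 30000 nM, and compound 1 is the one compound with a measured number, 16400 nM. Compound 4 `Cn1nc(Cc2nnc(SCCCCCCCC(=O)Nc3ccc(Cl)cc3Cl)n2CCCO)c2ccccc2c1=O` has not yet been measured. It differs from compound 3 by a hydrogen atom in place of a group of 7 heavy atoms (6 carbon, 1 silicon; no ring), on an oxygen on a saturated carbon. For the measured compounds named here, the only measured step at this end of the chain is an at least 1.8-fold higher number from compound 1 to compound 3 (0.26 log units; that floor lies within the scatter), too small to stand out, and it concerns a different group. Because (the limit of > 30000 nM in this assay, at which 2 of the 3 values shown sit), little room is left to read a direction. The expected step of a number no higher from compound 3 to compound 4 (the limit leaves the size open) is therefore none beyond the scatter, and compound 4 is estimated at 30000 nM, between 10000 nM and 100000 nM.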

Compound 4, half-maximal inhibitory concentration: > 30000 nM
Compound 4: only a limit was reported (the forecaster's own chance of this, stated with the estimate: 60%); the middle value sits exactly at the limit.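

Placing a hydrogen atom on the oxygen of compound 3 leaves the free alcohol compound 4 at > 30000 nM in this assay, which is a limit and not a number. With hydroxymethyl in place of diethoxymethyl, the change shows an at least 1.8-fold higher number from compound 1 to compound 4 (0.26 log units; that floor lies within the scatter). The step from compound 3 to compound 4 cannot be read, because both compounds sit at the same limit: the limit of > 30000 nM in this assay, at which 3 of the 4 values shown sit.

From the compounds shown here alone, whether any group at this chain end can give a clearly lower number stays open. An amine or a carboxylic acid in place of the hydroxyl would speak to that only if it gave a measured number.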